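Lengthening the chain of compound 2

The source may hold more compounds than are shown below. What is called first, only, known or untested is meant among the compounds shown, and "the series" means these compounds.

Measured in an ADME assay on microsomes from liver (Homo sapiens) for metabolic stability, read by LC-MS, using NADPH, with a stated time of 60 min; on this read-out lower numbers stand for a shorter-lived compound and higher numbers for a longer-lived compound:
- compound 1 `CCCCc1ccc(-c2nc(C)c(/C(C)=N/NC(=N)N)s2)cc1` gives 0.48 h
- compound 2 `CCCCOc1ccc(-c2nc(C)c(/C(C)=N/NC(=N)N)s2)cc1` gives > 4 h
- compound 3 `CCCCCCOc1ccc(-c2nc(C)c(/C(C)=N/NC(=N)N)s2)cc1` is not yet measured

Compound 2 gives only a limit, > 4 h, and not a number. This is the limit of > 4 h in this assay, at which 1 of the 2 values shown sits.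

Compound 3 differs from compound 2 by ethyl in place of hydrogen on a saturated chain carbon, four bonds along the chain from an oxygen on an aromatic ring. Within the data shown here, the one measured step, an at least 8.3-fold higher number from compound 1 to compound 2 (0.92 log units; beyond the scatter), is butoxy in place of butyl on an aromatic carbon, a change at another place, so its size does not carry over to this one. Going by these compounds, no step beyond the scatter is therefore expected in this assay, and the direction stays open. The expected step is a number no higher from compound 2 to compound 3 (the limit leaves the size open). Compound 3 is estimated at 4 h, with an expected range from 1.5 h to 10 h.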

Compound 3, half-life: > 4 h
Compound 3: no number, only a limit; the forecaster's own chance of this, stated with the estimate: 50%; the middle value lies on the limit itself.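

In this assay compound 3 gives > 4 h, which is a limit and not a number. Hexyloxy in place of butyl gives an at least 8.3-fold higher number from compound 1 to compound 3 (0.92 log units; beyond the scatter), so the longer chain on oxygen also stands clear of the butyl compound. The step between compound 2 and compound 3 cannot be read, as both stand at the same limit: the limit of > 4 h in this assay, at which 2 of the 3 values shown sit.

Going by these compounds, how far compound 2 and compound 3 lie past this limit stays open, and with it any effect of the added ethyl. On these data alone, whether octyloxy, or an amine in place of the chain, stays at this limit is also open.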